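A Fluorinated Ether in Place of a Propargyl Ether

A few compounds are considered here, and "the series" means these few. Any claim that something is new, unique, unknown or untested is made for them only; others in the source may bear on it.

Of the compounds shown here, three have so far been tested in a functional assay on B16 cells (Mus musculus) for cytotoxicity, read by MTT assay, with a stated time of 72 h; a higher number here means a weaker inhibitor, a lower number a stronger inhibitor. Compound 1 `COc1ccc(C(=O)c2cc(OC)c(OC)c(OC)c2)cc1N` gives 30 nM in this assay. Compound 2 `COc1cccc(/C=C/C(=O)Nc2cc(OC)c(OC)c(OC)c2)c1` gives 8500 nM in this assay. Compound 3 `C#CCOc1cccc(/C=C/C(=O)Nc2cc(C(=O)c3cc(OC)c(OC)c(OC)c3)ccc2OC)c1` gives 12200 nM in this assay, the highest of the three numbers. For the measured compounds named here, its nearest neighbour on that scale is compound 2, whose number lies within the usual scatter of the one for compound 3, so the two cannot be told apart on this evidence. Compound 1 stands far away, beyond the scatter, with a much lower number than compound 3.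

Compound 4 `COc1ccc(C(=O)c2cc(OC)c(OC)c(OC)c2)cc1NC(=O)/C=C/c1cccc(OC(F)(F)F)c1` is the next compound to be measured. It differs from compound 3 in one place: trifluoromethyl in place of propargyl on an oxygen on an aromatic ring. Going by the values given here, no pair of measured compounds that differ in only one place is available, so there is no measured step to lean on. The change swaps one small group for another of similar size on the same oxygen, and the rest of the structure is untouched. The expected step from compound 3 to compound 4 in this assay is therefore small, a 1.2-fold lower number from compound 3 to compound 4 (0.09 log units; within the scatter), not beyond the scatter in either direction. For compound 4 in this assay the estimate is 10000 nM, with a likely range from 4000 nM to 25000 nM.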

Compound 4, half-maximal inhibitory concentration: 6300 nM
For compound 4 the middle estimate is 1.6-fold (0.20 log units) above the measured one; measured number inside the range.
By their numbers in this assay, from the lowest: compound 1; then compounds 4, 2 and 3 (each within the scatter of the next).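

For the compounds shown here, this is the first step between two measured compounds that differ in one place, and in this assay it reads a 1.9-fold lower number from compound 3 to compound 4 (0.29 log units; within the scatter). On this oxygen on an aromatic ring, then, compound 3 and compound 4 cannot be told apart, even though the groups differ in kind: propargyl is three carbons with a triple bond, while trifluoromethyl is one carbon carrying three fluorines. No measurement here bears on the reason for this result, so the step stands as an observation without an explanation.

Going by these compounds, whether a hydroxyl group, a longer chain such as butoxy, or a carboxylic acid at this place would move the number beyond the usual scatter remains open. On these data alone, it also remains open whether trifluoromethyl in place of propargyl would give an equally small step on a different parent compound, as this single pair is the only one available.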